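Replacing the Hydroxy of Compound 2 with Methyl

The source may hold more compounds than are shown below. What is called first, only, known or untested is meant among the compounds shown, and "the series" means these compounds.

Measured compounds in a functional assay on SGC-7901 cells (Homo sapiens) for antiproliferative activity, read by MTT assay, with a stated time of 72 h; on this read-out lower numbers stand for stronger inhibition and higher numbers for weaker inhibition:
- compound 1 `COc1ccc(-c2ccc3ncn(-c4cc(OC)c(OC)c(OC)c4)c3c2)cc1O`: 44 nM
- compound 2 `COc1cc(-n2cnc3ccc(-c4cccc(O)c4)cc32)cc(OC)c1OC`: 53 nM

In this assay, among the measured compounds shown here, compound 2 cannot be separated from compound 1, the only other compound measured. For the measured compounds named here, the one measured step, replacing methoxy with hydrogen, gave a 1.2-fold higher number from compound 1 to compound 2 (0.08 log units; within the scatter). Compound 3 `COc1cc(-n2cnc3ccc(-c4cccc(C)c4)cc32)cc(OC)c1OC` follows from compound 2 by a single change, methyl in place of hydroxy on an aromatic carbon, meta to a large group, or 3-hydroxyphenyl to 3-methylphenyl: methyl in place of hydroxy on an aromatic carbon. Going by the values given here, the measured step left the hydroxy in place, so it bears on this change only weakly, and no measured compound shows what replacing the hydroxy does. A moderate rise in the number is therefore expected in this assay, though this is a judgement with wide uncertainty. The estimated change is a 2.1-fold higher number from compound 2 to compound 3 (0.32 log units; beyond the scatter). For compound 3 the expected value is 110 nM, with an estimated range of 35 nM to 350 nM.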

Compound 3, half-maximal inhibitory concentration: 1240 nM
The estimate for compound 3 lay 11-fold (1.05 log units) below the measured number; the measured number lies above the stated range.
By their numbers in this assay, from the lowest: compounds 1 and 2 (each within the scatter of the next); then compound 3.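

Methyl in place of hydroxy gives a 23-fold higher number from compound 2 to compound 3 (1.37 log units; beyond the scatter) in this assay and so shows that this position, meta to a large group, is sensitive to the change, whereas the earlier step from compound 1 to compound 2, which kept the hydroxy, stayed within the scatter. The change from 3-hydroxy-4-methoxyphenyl to 3-methylphenyl gives a 28-fold higher number from compound 1 to compound 3 (1.45 log units; beyond the scatter) in this assay and is likewise large. Nothing available explains this rise.

Going by these compounds, whether the hydroxy itself is needed, or whether an amine or a carboxylic acid in its place would keep the number close to that of compound 2, remains open. Also open, on these data alone, is whether methyl would cost as much on the 3-hydroxy-4-methoxyphenyl group of compound 1, with the methoxy kept.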